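This account rests on a few compounds, and the source may have more. Where it says the series, first, only, none or still open, it means among the compounds named here.

Within the data shown here, compound 1 `Cc1[nH]c(=O)n(C2CCCCC2)c1-c1ccccc1` gives 47600 nM in a functional assay on brain (Rattus norvegicus, strain Wistar) for inhibition (a higher number here means a weaker inhibitor, a lower number a stronger inhibitor), the highest of the two numbers measured so far; the nearest is compound 2 `Cc1[nH]c(=O)n(C2CCCCC2)c1-c1cccc(OC(C)C)c1`, which in this assay gives 10400 nM. Compound 3 `CCCCCCCCc1ccc(-c2c(C)[nH]c(=O)n2C2CCCCC2)cc1` differs from compound 1 by octyl in place of hydrogen on an aromatic carbon. Among the measured compounds shown here, the only measured step that bears on this change is the one where isopropoxy replaces hydrogen on an aromatic carbon, a 4.6-fold lower number from compound 1 to compound 2 (0.66 log units; beyond the scatter). Octyl is likewise a substituent on the six-membered aromatic ring of carbon only, but a chain without ring or heteroatom, so the size of the step cannot be read directly from compound 2. Substitution on that ring has so far lowered the number, and a step in this assay of similar or somewhat larger size in the same direction is expected. For compound 3 the estimated step is a 7.9-fold lower number from compound 1 to compound 3 (0.90 log units; beyond the scatter). The number expected for compound 3 in this assay is 6000 nM, with a range of 1500 nM to 25000 nM.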

Compound 3, half-maximal inhibitory concentration: 10300 nM
Compound 3: the middle estimate sits 1.7-fold (0.23 log units) below what was measured; measured number inside the range.
By their numbers in this assay, from the lowest: compounds 3 and 2 (each within the scatter of the next); then compound 1.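

In this assay, the carbon para to a large group on the six-membered aromatic ring of carbon only accepts octyl, with a 4.6-fold lower number from compound 1 to compound 3 (0.66 log units; beyond the scatter). A lower number on this ring therefore does not need the oxygen of the isopropoxy group: octyl brings 8 carbon atoms, no ring and no hydrogen-bond acceptors. The printed size of this step matches that of a 4.6-fold lower number from compound 1 to compound 2 (0.66 log units; beyond the scatter), even though the two groups differ in kind and in where they sit on the ring.

Still open, from the compounds shown here alone, is how the number responds to chain length at this carbon, from a shorter butyl chain to a longer dodecyl chain. An amine or a carboxylic acid at the end of the chain would test whether a polar end group is accepted there. No measurement here explains the result.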